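Cyclopentyl for dimethylamino at the aminopyrimidine carbon: working notes

The source may report more compounds than this note shows. Statements on the series, on what has been measured and on what is new or still open speak of the compounds shown alone.

Compound 3 `CN(C)c1cc(-c2cc(N3C[C@H](O)[C@@H](O)C3)ccc2O)nc(N)n1` stands as "not determined" (no result reported) in a functional assay on A549 cells (Homo sapiens) for cytotoxicity, with a stated time of 48 h; a higher number here means a weaker inhibitor of growth, a lower number a stronger inhibitor of growth; its position on the numbers cannot be stated. The related analogues set the range: compound 1 `Cc1cc(-c2cc(N3C[C@H](O)[C@@H](O)C3)ccc2O)nc(N)n1` gives 2000 nM in this assay, and compound 2 `Nc1nc(NC2CCCCC2)cc(-c2cc(N3C[C@H](O)[C@@H](O)C3)ccc2O)n1` gives 1500 nM. Going by the values given here, the one measured step at that aromatic carbon, a 1.3-fold lower number from compound 1 to compound 2 (0.12 log units; within the scatter), is within the scatter. Compound 4 `Nc1nc(-c2cc(N3C[C@H](O)[C@@H](O)C3)ccc2O)cc(C2CCCC2)n1` differs from compound 3 by cyclopentyl in place of dimethylamino on an aromatic carbon. The step bearing on it is the same-position change from compound 1 to compound 2, which was small, so no step beyond the scatter is expected in this assay in either direction. Compound 4 is therefore estimated at 1800 nM, with a range of 600 nM to 5500 nM.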

Compound 4, concentration for 50% growth inhibition: 2000 nM
Compound 4: middle estimate off by 1.1-fold (0.05 log units), on the low side; low and high end bracket the measured number.
By their numbers in this assay, from the lowest: compounds 2, 1 and 4 (each within the scatter of the next).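

In this assay the change to cyclopentyl gives a 1.3-fold higher number from compound 2 to compound 4 (0.12 log units; within the scatter) and no change at the digits printed from compound 1 to compound 4 (within the scatter) at this aromatic carbon. A ring of carbon only, with no hydrogen-bond donors or acceptors, therefore sits level with both methyl and cyclohexylamino, and these three groups do not separate in this read-out. No available evidence accounts for this flat result.

As far as these compounds go, whether a carboxylic acid, a primary amine or a longer chain at this carbon would move the number beyond the scatter remains open. From the compounds shown here alone, the standing of dimethylamino in compound 3 relative to these three groups also remains open.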